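The compounds below may be only part of what the source reports. "The series", "measured", "known", "first", "only" and "open" are said of these compounds alone.

Measured compounds and their values in a physicochemical assay for solubility, in phosphate buffer, at pH 6.5; on this read-out lower numbers stand for lower solubility and higher numbers for higher solubility:

compound 1 `CNc1nc(NCCCN(C)C)c2sc(-c3ccc(S(C)(=O)=O)cc3)cc2n1` gives 25 ug/mL.
compound 2 `CNc1nc(NCCCN(C)C)c2sc(-c3cccc(C#N)c3)cc2n1` gives 25 ug/mL.
compound 3 `CNc1nc(NCCCN(C)C)c2sc(-c3ccc(C(F)(F)F)cc3Cl)cc2n1` gives > 100 ug/mL, which is a limit of the assay and not a number.

Compound 2 stands level with compound 1 in this assay at the digits shown, the two values lying within the usual scatter, so no order between them can be read. Compound 3 sits at the limit of > 100 ug/mL in this assay, at which 1 of the 3 values shown sits, and nothing more than that is known of it. For the measured compounds named here, no pair of measured compounds differs in only one place, so no measured step is available to set the size of the change now considered.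

The unmeasured compound 4 `CNc1nc(NCCCN(C)C)c2sc(-c3ccccc3)cc2n1` differs from compound 2 only in hydrogen in place of cyano on an aromatic carbon. Going by the values given here, nothing among the measured compounds shows what a loss of the cyano group does in this assay. The expectation for the step of a 1.3-fold lower number from compound 2 to compound 4 (0.10 log units; within the scatter) is therefore for no change beyond the scatter, with a slight lean towards a lower value. On that basis compound 4 is estimated at 20 ug/mL, with a range from 8 ug/mL to 60 ug/mL.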

Compound 4, solubility: > 100 ug/mL
Compound 4: only a limit was reported; the forecaster's own chance of this, stated with the estimate: 5%; middle value at least 5.0-fold (0.69 log units) from the limit.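

In this assay compound 4, which carries a plain phenyl, gives > 100 ug/mL, and this is a limit of the assay and not a number. For the compounds shown here, this provides the first measured single-place changes: hydrogen in place of cyano is an at least 4.0-fold higher number from compound 2 to compound 4 (0.60 log units; beyond the scatter), and hydrogen in place of methylsulfonyl is an at least 4.0-fold higher number from compound 1 to compound 4 (0.60 log units; beyond the scatter), so the group on this phenyl is not neutral in this assay, although the shared values of the two substituted compounds could not show this on their own. Both steps are lower bounds only, and their full size cannot be read, with the top of the range now more crowded: the limit of > 100 ug/mL in this assay, at which 2 of the 4 values shown sit.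

No general rule that substitution on this phenyl lowers the number can be claimed, as compound 3 carries chloro and trifluoromethyl on the phenyl and is also reported only as a limit. On these data alone, whether a methoxy, a primary amine or a carboxylic acid on the same aromatic carbon would read like cyano or like hydrogen remains open, as does any difference between the two groups at a single position.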